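The source may report more compounds than this note shows. Statements on the series, on what has been measured and on what is new or still open speak of the compounds shown alone.

Measured so far:
- compound 1 `CC(C)C(c1nnc[nH]1)c1ccc(-c2ccc3cccc(F)c3c2)[nH]c1=O` gives 0.552 h in an ADME assay on microsomes from liver (Rattus norvegicus) for metabolic stability; on this read-out lower numbers stand for a shorter-lived compound and higher numbers for a longer-lived compound
- compound 2 `CC(C)C(c1ccc(-c2ccc3cccc(F)c3c2)[nH]c1=O)N1CCN/C1=N\C#N` gives 0.327 h in this assay
- compound 3 `CC(C)C(c1noc(=O)[nH]1)c1ccc(-c2ccc3cccc(F)c3c2)[nH]c1=O` gives > 3 h in this assay

For compound 3 the value is a limit of this assay and not a number, as the evidence notes: the limit of > 3 h in this assay, at which 1 of the 3 values shown sits. Compound 3 therefore stands at the top of the three values shown, and the two steps that lead to it are both clear: an at least 5.4-fold higher number from compound 1 to compound 3 (0.73 log units; beyond the scatter) and an at least 9.1-fold higher number from compound 2 to compound 3 (0.96 log units; beyond the scatter). The step between compound 1 and compound 2 is small: a 1.7-fold lower number from compound 1 to compound 2 (0.23 log units; within the scatter).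

Compound 4 `CC(C)C(CC(N)=O)c1ccc(-c2ccc3cccc(F)c3c2)[nH]c1=O` differs from compound 3 in one place: a group of 4 heavy atoms (2 carbon, 1 nitrogen, 1 oxygen; no ring) in place of a group of 6 heavy atoms (2 carbon, 2 nitrogen, 2 oxygen; one five-membered aromatic ring with 3 hetero atoms), on a saturated chain carbon bound to an aromatic carbon and a saturated chain carbon. Within the data shown here, the steps that bear on this change are those into compound 3 from compound 1 and compound 2, where the six-atom ring entering lifted the number by at least a modest amount each time. Its removal in compound 4 is therefore expected to lower the number again, with an expected step of an at least 3.0-fold lower number from compound 3 to compound 4 (0.47 log units; beyond the scatter). Compound 4 is expected to sit near 1 h in this assay, between 0.3 h and 3 h.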

Compound 4, half-life: < 0.0667 h
Compound 4: no number, only a limit (the forecaster's own chance of this, stated with the estimate: 20%); at least 14-fold (1.17 log units) between middle value and limit.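

The value of compound 4 is a limit of the assay and not a number: the limit of < 0.0667 h in this assay, at which 1 of the 4 values shown sits. In this assay, carbamoylmethyl, which has no ring, stands lowest of the groups at this place, with all three steps beyond the scatter: an at least 44-fold lower number from compound 3 to compound 4 (1.65 log units; beyond the scatter), an at least 4.9-fold lower number from compound 2 to compound 4 (0.69 log units; beyond the scatter) and an at least 8.2-fold lower number from compound 1 to compound 4 (0.91 log units; beyond the scatter). Among these compounds, each of the three ring-bearing compounds therefore lasts longer than the open-chain compound 4, and this place spans a wider range than the earlier compounds showed.

As far as these compounds go, how far the true values lie beyond the limits of compound 3 and compound 4 remains open, so the full span is unknown. Also open, from the compounds shown here alone, is where a carboxylic acid, an amine or a longer chain carrying the same amide would fall at this place.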